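The source may hold more compounds than are shown below. What is called first, only, known or untested is meant among the compounds shown, and "the series" means these compounds.

Working notes, ester series in an assay on HeLa cells for displacement of a labelled ligand from adenosine receptor A3 (Homo sapiens), read by radioligand binding, with a stated time of 180 min, tested at 1 uM; a higher number here means more inhibition at the concentration tested (going by the name of the read-out), a lower number less inhibition.

Compound 3 `CC(C)OC(=O)C1=C(C(F)(F)F)NC(=O)NC1c1ccoc1` gives 1% in this assay. Compound 2 `CCOC(=O)C1=C(C(F)(F)F)NC(=O)NC1c1cccs1` gives 1%, which is level with compound 3 at the digits shown, and together these two are the lowest of the three numbers. Compound 1 `CC(C)OC(=O)C1=C(C(F)(F)F)NC(=O)NC1c1ccsc1` gives 3%, the furthest from compound 3, yet the step of a number 2 percentage points lower from compound 1 to compound 3 (within the scatter) is within the scatter, so the furan-3-yl for thiophen-3-yl exchange on the saturated ring carbon has no visible effect here. All three measured values sit close to the floor of the read-out.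

Compound 4 `CCOC(=O)C1=C(C(F)(F)F)NC(=O)NC1c1ccoc1` has not yet been measured. It differs from compound 3 as follows: hydrogen in place of methyl on a saturated chain carbon bound to an oxygen next to a carbonyl group and a saturated chain carbon. Among the compounds with values here, no measured pair isolates this ester change on its own; the only single-point step known, from compound 1 to compound 3, concerns the aromatic ring and not the isopropoxycarbonyl to ethoxycarbonyl cut. Since every measured compound is near the floor regardless of ester or ring, no step beyond the scatter is expected in this assay, and the estimated step is a number 1 percentage points higher from compound 3 to compound 4 (within the scatter). Compound 4 is therefore expected to give about 2% in this assay, with a range of -6% to 12%.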

Compound 4, a percentage reported as inhibition, at one concentration (the size of the read-out at that concentration, not a potency): 1%
Compound 4: the middle estimate sits 1 percentage points above what was measured, within the range that was stated.
By their numbers in this assay, from the lowest: compounds 2, 3, 4 and 1 (each within the scatter of the next).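

In this assay, within the data shown here, the ester can be read on its own for the first time: with furan-3-yl held fixed, the isopropoxycarbonyl to ethoxycarbonyl cut gives no change at the digits printed from compound 3 to compound 4 (within the scatter) and thus no effect that stands clear of the scatter. Hydrogen in place of methyl on this saturated chain carbon therefore leaves the number at the floor of the read-out, as far as this single pair can show. With ethoxycarbonyl held fixed, the ring can now also be read in this ester, and changing the ring gives no change at the digits printed from compound 2 to compound 4 (within the scatter) in the same flat range. No outside data bear on these flat numbers.

Among these compounds, since every step so far starts and ends at the floor, these compounds cannot show whether the ester position has any influence on inhibition in this assay at the single concentration tested. On these data alone, whether a longer chain such as butyl on the ester oxygen, a free carboxylic acid at this position, or a phenyl group in place of the small ring on the saturated ring carbon would give a number clear of the floor remains open.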